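Benzothiazolyl ethers in the writhing test: next step

The compounds below may be only part of what the source reports. "The series", "measured", "known", "first", "only" and "open" are said of these compounds alone.

Measured so far, all in a functional assay on the whole organism with Mus musculus as the target, in the writhing test, at a dose of 100 mg/kg by the intraperitoneal route; on this read-out lower numbers stand for less inhibition and higher numbers for more inhibition at the one dose given (going by the name of the read-out):
- compound 1 `Brc1ccc(OCCOc2nc3ccccc3s2)c(Br)c1` gives 68.6%
- compound 2 `c1ccc(COc2nc3ccccc3s2)cc1` gives 51.9%
- compound 3 `Cc1ccc(COc2nc3ccccc3s2)cc1` is reported as "not active" (no number reported)

Compound 3 stands at the bottom of what has been measured: it carries no number at all, only the report "not active" (no number reported), so it cannot be placed on the same scale as compound 1 or compound 2. Compound 2 shares the benzyl ether with compound 3, and compound 2 gives 51.9% in this assay, while compound 1 gives 68.6%.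

The next compound, compound 4 `FC(F)(F)c1ccc(COc2nc3ccccc3s2)cc1`, differs from compound 3 by trifluoromethyl in place of methyl on an aromatic carbon. Within the data shown here, no measured pair tells how large such a step should be. Since compound 3 starts from no reported activity, any step in this assay can only run upward or stay flat; a modest rise is expected, but a flat outcome within the scatter is also plausible, as compound 2 with nothing at that place already sits well below compound 1.

For compound 4 the expected inhibition in this assay is 35%, with a range from 0% to 65%.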

Compound 4, a percentage reported as inhibition, in the whole organism at one dose (the size of the read-out at that dose, not a potency): 99.6%
Estimate against measurement, compound 4: 64.6 percentage points below; measured number above the stated range.
By their numbers in this assay, from the lowest: compound 2; then compound 1; then compound 4.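

In this assay, the place para to a large group on the benzyl ring proves highly sensitive to substitution: trifluoromethyl in place of hydrogen gives a number 47.7 percentage points higher from compound 2 to compound 4 (beyond the scatter) in this series. The earlier compounds shown here offered only compound 3, with methyl at this place and the report "not active", whereas compound 4, with trifluoromethyl at the same place, gives 99.6% as a number, so the two groups are not interchangeable here. Nothing at hand gives a reason for this difference.

As far as these compounds go, whether an amine, a carboxylic acid or a methoxy group at this place would hold the inhibition stays open, as does the effect of a longer chain between the ether oxygen and this ring. All values come from a single dose, so the relative potency of these compounds also stays open.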